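A Nitro Group Added to an Inactive Starting Point

The compounds below may be only part of what the source reports. "The series", "measured", "known", "first", "only" and "open" are said of these compounds alone.

Compound 1 `CC1(C)Cc2c(ccc(C(=O)/C=C/c3cn(-c4ccccc4)nc3-c3ccccc3)c2OCc2ccccc2)O1` was tested in a functional assay on PC-3 cells (Homo sapiens) for antiproliferative activity, read by MTT assay, with a stated time of 48 h; on this read-out lower numbers stand for stronger inhibition and higher numbers for weaker inhibition. In this assay compound 1 gives only a limit, > 100000 nM, and no actual number. Compound 2 `CC1(C)Cc2c(ccc(C(=O)/C=C/c3ccccc3)c2OCc2ccccc2)O1` likewise sits at the limit in this assay, > 100000 nM. Compound 3 `CC1(C)Cc2c(OCc3ccccc3)ccc(C(=O)/C=C/c3ccc(Br)cc3)c2O1` also returns only a limit, > 100000 nM. Because (the limit of > 100000 nM in this assay, at which 3 of the 3 values shown sit), compound 1 stands level with every other measured compound, and no order of potency can be read among them. Compound 4 `CC1(C)Cc2c(ccc(C(=O)/C=C/c3cn(-c4ccccc4)nc3-c3cccc([N+](=O)[O-])c3)c2OCc2ccccc2)O1` differs from compound 1 in a single place: nitro in place of hydrogen on an aromatic carbon. Going by the values given here, no pair of measured compounds shows what such a change does, so its size can only be guessed. With every measured value resting at the limit, the step from compound 1 to compound 4 is expected to be small, a number no higher from compound 1 to compound 4 (the limit leaves the size open), and in no direction that goes beyond the scatter. Compound 4 is thus expected to give about 100000 nM, somewhere between 30000 nM and 300000 nM, and most likely once more only as a limit.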

Compound 4, half-maximal inhibitory concentration: > 100000 nM
Compound 4: a limit, no number; the forecaster's own chance of this, stated with the estimate: 75%; the middle value lies on the limit itself.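

Compound 1 and compound 4 both give a limit rather than an actual number, so no step between them can be read: the limit of > 100000 nM in this assay, at which 4 of the 4 values shown sit.

The compounds shown leave open whether nitro in place of hydrogen on an aromatic carbon changes the inhibition at all.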